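Ring size at the amide nitrogen: compound 2 to compound 4

The source may hold more compounds than are shown below. What is called first, only, known or untested is meant among the compounds shown, and "the series" means these compounds.

Compound 1, `CC(C)=CCC/C(C)=C/CC/C(C)=C/CSC[C@H](NC(=O)CCCCCN1CCN(C)CC1)C(=O)NC1CCCCCC1`: 5.44
Compound 2, `CC(C)=CCC/C(C)=C/CC/C(C)=C/CSC[C@H](NC(=O)CCCCCN1CCCC1)C(=O)NC1CCCCCC1`: 4.93
Compound 3, `CC(C)=CCC/C(C)=C/CC/C(C)=C/CSC[C@H](NC(=O)CCCCCN1CCN(C)CC1)C(=O)NC1CCCC1`: 4.55

All three share one core; they differ at the chain-terminal amine and at the group on the amide-type nitrogen. In a physicochemical assay for lipophilicity (a lower number here means a more polar compound, a higher number a more lipophilic compound), compound 2 stands second highest of the three numbers, with compound 3 nearest to it and compound 1 furthest. The two measured steps are a number 0.51 log units lower from compound 1 to compound 2 (beyond the scatter) and a number 0.89 log units lower from compound 1 to compound 3 (beyond the scatter); both are beyond the scatter and of modest size.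

Compound 4, `CC(C)=CCC/C(C)=C/CC/C(C)=C/CSC[C@H](NC(=O)CCCCCN1CCCC1)C(=O)NC1CC1`, is not yet measured. It differs from compound 2 as follows: cyclopropyl in place of cycloheptyl on an amide-type nitrogen. The step from compound 1 to compound 3 bears on this change directly, since it exchanges the same cycloheptyl at the same amide-type nitrogen for a smaller ring; the present change removes more of the ring. A drop larger than that step is therefore expected, in the same direction. The expected step is a number 1.63 log units lower from compound 2 to compound 4 (beyond the scatter), and compound 4 is estimated at 3.3, within a range from 2.7 to 3.9.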

Compound 4, distribution coefficient: 3.15
Beside the measured number, compound 4's estimate is 0.15 log units above it, and the stated range covers the measured number.
By their numbers in this assay, from the lowest: compound 4; then compound 3; then compound 2; then compound 1.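

In this assay, cyclopropyl in place of cycloheptyl on the amide-type nitrogen gives a large step, a number 1.78 log units lower from compound 2 to compound 4 (beyond the scatter), with pyrrolidin-1-yl at the chain end. The earlier step, a number 0.89 log units lower from compound 1 to compound 3 (beyond the scatter), has cyclopentyl as the entering ring and 4-methylpiperazin-1-yl at the chain end, so a fall on replacing cycloheptyl with a smaller ring at this nitrogen now appears with both chain-terminal amines. No measurement on hand gives a reason for the size of either step.

The two ring changes stand on different chain-terminal amines, so their sizes do not yet form a ring-size series on one background. As far as these compounds go, how cyclobutyl, cyclohexyl or an open chain such as n-butyl on this nitrogen would fall relative to these rings remains open.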